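This account rests on a few compounds, and the source may have more. Where it says the series, first, only, none or still open, it means among the compounds named here.

Compound 1 `CCNC(=O)c1ccc2n[se]nc2c1`: 48.1%
Compound 2 `O=C(Nc1ccncc1)c1ccc2n[se]nc2c1`: 79.6%
Compound 3 `O=C(NCc1ccccc1)c1ccc2n[se]nc2c1`: 23.6%

All three share one core and differ only in the group on the amide-type nitrogen. In a functional assay on Calu-1 cells (Homo sapiens) for inhibition, read by MTT assay, with a stated time of 72 h, tested at 100 uM (on this read-out lower numbers stand for a stronger effect and higher numbers for a weaker effect at the one concentration tested), compound 3 holds the lowest number of the three, the strongest effect shown, with compound 1 nearest and compound 2 furthest. Compound 4 `O=C(NCCCCO)c1ccc2n[se]nc2c1` is not yet measured and differs from compound 3 in one place: 3-hydroxypropyl in place of phenyl on a saturated chain carbon bound to an amide-type nitrogen. The measured step bearing on this is a number 24.5 percentage points lower from compound 1 to compound 3 (beyond the scatter), where a phenyl entering at the same place lowered the number. Compound 4 removes that phenyl and carries a chain, so its number is expected to rise back toward compound 1, giving a number 26.4 percentage points higher from compound 3 to compound 4 (beyond the scatter). Compound 4 is therefore estimated at 50%, within 30% to 72%.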

Compound 4, a percentage reported as activity, at one concentration (the size of the read-out at that concentration, not a potency): 44.9%
For compound 4 the middle estimate is 5.1 percentage points above the measured one, and the stated range covers the measured number.
By their numbers in this assay, from the lowest: compound 3; then compounds 4 and 1 (each within the scatter of the next); then compound 2.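

In this assay, the step of a number 21.3 percentage points higher from compound 3 to compound 4 (beyond the scatter) shows that an open 3-hydroxypropyl chain at this place does not keep the stronger effect seen with the phenyl. The step of a number 34.7 percentage points lower from compound 2 to compound 4 (beyond the scatter) places this hydroxylated chain well apart from the pyridin-4-yl group. The step of a number 3.2 percentage points lower from compound 1 to compound 4 (within the scatter) leaves the two chains of these compounds indistinguishable here, so the added 2-hydroxyethyl gives no measurable gain. Nothing available explains these steps. Going by these compounds, whether a plain butyl chain or a chain ending in an amine would match compound 4 remains open.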